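Extending the aryl arm with a styryl linker on compound 3

A few compounds are considered here, and "the series" means these few. Any claim that something is new, unique, unknown or untested is made for them only; others in the source may bear on it.

Compound 3 `COc1ccc(-c2cc(C(C)=O)c3[nH]c(-c4ccc(OC)cc4)cc3c2)cc1` gives 20.2% in a functional assay on HeLa cells (Homo sapiens) for cytotoxicity, read by MTT assay, with a stated time of 2 days, tested at 100 uM (a lower number here means a stronger effect, a higher number a weaker effect of the compound at the concentration tested), the lowest of the three numbers. Compound 1 `COc1ccc(-c2cc(C(C)=O)c3[nH]c(-c4ccc(F)cc4)cc3c2)cc1` gives 20.6%, and the step of a number 0.4 percentage points lower from compound 1 to compound 3 (within the scatter) lies within the scatter. Compound 2 `COc1ccc(-c2cc3cc(-c4ccc(F)cc4)cc(C(C)=O)c3[nH]2)cc1` gives 46.5%, and the step of a number 26.3 percentage points lower from compound 2 to compound 3 (beyond the scatter) is modest. Compound 4 `COc1ccc(-c2cc3cc(/C=C/c4ccc(F)cc4)cc(C(C)=O)c3[nH]2)cc1` differs from compound 3 by 2-(4-fluorophenyl)ethenyl in place of 4-methoxyphenyl on an aromatic carbon. Going by the values given here, no measured step swaps an aryl group for a 2-(4-fluorophenyl)ethenyl group, so only the fluoro-bearing compound 1, with its 20.6%, offers loose guidance. A step of about a number 4.8 percentage points higher from compound 3 to compound 4 (within the scatter) is therefore expected, likely within the scatter, with a wide margin either way. Compound 4 is estimated at 25%, ranging from 10% to 50%.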

Compound 4, a percentage reported as activity, at one concentration (the size of the read-out at that concentration, not a potency): 18.9%
The estimate for compound 4 lay 6.1 percentage points above the measured number; the measured number falls inside the stated range.
By their numbers in this assay, from the lowest: compounds 4, 3 and 1 (each within the scatter of the next); then compound 2.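

In this assay, the 2-(4-fluorophenyl)ethenyl arm has a stronger effect than the 4-fluorophenyl group it replaces at this position, with a number 27.6 percentage points lower from compound 2 to compound 4 (beyond the scatter), a modest step. Against the 4-methoxyphenyl group the result is a number 1.3 percentage points lower from compound 3 to compound 4 (within the scatter), so this position accepts a longer arm holding a double bond with no loss of effect. Nothing available explains either step. Going by these compounds, it remains open whether the double bond itself matters, which a saturated ethyl linker could test, and whether an amine or a carboxylic acid on the arm would keep the number this low.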